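This account rests on a few compounds, and the source may have more. Where it says the series, first, only, none or still open, it means among the compounds named here.

In a functional assay on SF-295 cells (Homo sapiens) for antiproliferative activity, read by sulforhodamine B assay, with a stated time of 72 h (on this read-out lower numbers stand for stronger inhibition and higher numbers for weaker inhibition), compound 1 `Clc1ccc(C(/C=C/c2ccccc2)=N\Nc2nncc3ccccc23)cc1` gives 0.53 nM, compound 2 `O=C1CS/C(=N/Nc2nncc3ccccc23)N1c1ccccc1` gives 4.6 nM and compound 3 `Cc1cc(NS(=O)(=O)c2ccc(Nc3nncc4ccccc34)cc2)no1` gives 4.4 nM. Compound 3 stands second highest of the three numbers in this assay; its value sits within the scatter of that of compound 2, while compound 1 gives a clearly lower number, beyond the scatter. Compound 4 `Cc1cc(C)nc(NS(=O)(=O)c2ccc(Nc3nncc4ccccc34)cc2)n1` has not yet been measured in this assay. Compared with compound 3 it carries 4,6-dimethylpyrimidin-2-yl in place of 5-methyl-1,2-oxazol-3-yl on a sulfonamide nitrogen. Among the measured compounds shown here, no measured pair shows a step of this kind, so nothing here tells its size; the step is expected to stay within the scatter, with no direction claimed. The expected step is a 1.1-fold higher number from compound 3 to compound 4 (0.06 log units; within the scatter). Compound 4 is thus estimated at 5 nM, with a range from 1.5 nM to 16 nM.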

Compound 4, half-maximal inhibitory concentration: 0.56 nM
Beside the measured number, compound 4's estimate is 8.9-fold (0.95 log units) above it; measured number below the stated range.
By their numbers in this assay, from the lowest: compounds 1 and 4 (each within the scatter of the next); then compounds 3 and 2 (each within the scatter of the next).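

The sulfonamide nitrogen is sensitive to the group it carries: in this assay, 4,6-dimethylpyrimidin-2-yl in place of 5-methyl-1,2-oxazol-3-yl gives a 7.9-fold lower number from compound 3 to compound 4 (0.90 log units; beyond the scatter). Among the compounds shown here, this is the first single-place step, and it lies beyond the scatter, even though both groups are aromatic rings with matching hydrogen-bond donor and acceptor counts. No measured evidence bears on the origin of this step.

Going by these compounds, it remains open whether the step follows the six-membered ring or its methyl groups. On these data alone, how an unsubstituted pyrimidin-2-yl or a phenyl group on this nitrogen would read is also open.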